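A few compounds are considered here, and "the series" means these few. Any claim that something is new, unique, unknown or untested is made for them only; others in the source may bear on it.

Compound 1 `COc1ccc2nc(Cl)c(C3CC(c4ccc(C)cc4)=NN3c3nc(-c4ccc(Cl)cc4)cs3)cc2c1`: 38 nM
Compound 2 `COc1ccc2nc(Cl)c(C3CC(c4ccc(C)cc4)=NN3c3nc(C)c(/N=N/c4ccccc4)s3)cc2c1`: 38 nM
Compound 3 `COc1ccc2nc(O)c(/C=C/C(=O)c3ccc(C)cc3)cc2c1`: 38 nM

In a functional assay on DLD-1 cells (Homo sapiens) for antiproliferative activity (a higher number here means a weaker inhibitor, a lower number a stronger inhibitor), compound 1 stands level with compound 2 and compound 3, with nothing separating the three beyond the scatter. The next compound, compound 4 `COc1ccc2nc(Cl)c(C3CC(c4ccc(C)cc4)=NN3c3nc(-c4ccc(C)cc4)cs3)cc2c1`, differs from compound 1 in one place: methyl in place of chloro on an aromatic carbon, para to a large group, so that 4-chlorophenyl becomes 4-methylphenyl (methyl in place of chloro on an aromatic carbon). Among the compounds with values here, no pair of measured compounds shows this exchange, so the data offer no direct guide to it. The only indication is that three structurally different compounds read alike, with compound 1 at 38 nM, compound 2 at 38 nM and compound 3 at 38 nM in the same assay. On that slender basis, no step beyond the scatter is expected in this assay, and neither direction is favoured. The estimated step of a 1.1-fold higher number from compound 1 to compound 4 (0.02 log units; within the scatter) is correspondingly small. Compound 4 is estimated at 40 nM, with an expected range from 18 nM to 95 nM.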

Compound 4, half-maximal inhibitory concentration: 38 nM
Compound 4: the middle estimate sits 1.1-fold (0.02 log units) above what was measured; the measured number falls inside the stated range.
By their numbers in this assay, from the lowest: compounds 1, 2, 3 and 4 (each within the scatter of the next).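

In this assay the exchange of chloro for methyl on an aromatic carbon, para to a large group, reads as no change at the digits printed from compound 1 to compound 4 (within the scatter) and turns 4-chlorophenyl into 4-methylphenyl. Within the data shown here, this gives the first direct reading at this position, which the earlier compounds, differing from one another in more than one place, could not supply. For these two groups, the read-out does not distinguish between them on the 1,3-thiazol-2-yl group. The data offer no measurement that would explain why the two compounds read alike.

On these data alone, what an amine, a carboxylic acid or a longer chain on the same aromatic carbon would do to the number stays open. Equally open, as far as these compounds go, is whether methyl on another carbon of the same ring would leave the number unchanged.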